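Replacing the 1-methyl-1H-indol-5-yl group of compound 3

The source may report more compounds than this note shows. Statements on the series, on what has been measured and on what is new or still open speak of the compounds shown alone.

Measured in a functional assay on HCT-116 cells (Homo sapiens) for inhibition, read by CCK-8 assay, with a stated time of 48 h; on this read-out higher numbers stand for weaker inhibition and lower numbers for stronger inhibition:
- compound 1 `COc1cc(-c2ccnc3cc(-c4ccc(F)cc4)nn23)cc(OC)c1OC`: 5030 nM
- compound 2 `COc1cc(-c2ccnc3cc(-c4cccc(C#N)c4)nn23)cc(OC)c1OC`: > 10000 nM (a limit of the assay, not a number)
- compound 3 `COc1cc(-c2ccnc3cc(-c4ccc5c(ccn5C)c4)nn23)cc(OC)c1OC`: 39 nM

Compound 3 has the lowest value of the series, 39 nM. Compound 4 `COc1cc(-c2ccnc3cc(-c4ccc(C(F)(F)F)cc4)nn23)cc(OC)c1OC` keeps the shared core and differs from it in one group: 4-(trifluoromethyl)phenyl in place of 1-methyl-1H-indol-5-yl on an aromatic carbon. Among the measured compounds shown here, two measured steps bear on this, and both installed that same 1-methyl-1H-indol-5-yl group in place of a substituted phenyl: a 130-fold lower number from compound 1 to compound 3 (2.11 log units; beyond the scatter) and an at least 250-fold lower number from compound 2 to compound 3 (2.40 log units; beyond the scatter). Both were large. Compound 4 again carries a substituted phenyl, so a large step towards a higher number is expected in this assay. The expected change is a 150-fold higher number from compound 3 to compound 4 (2.19 log units; beyond the scatter). For compound 4 the estimated value is 6000 nM, with an expected range of 2000 nM to 18000 nM.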

Compound 4, half-maximal inhibitory concentration: 1860 nM
Compound 4: middle estimate off by 3.2-fold (0.51 log units), on the high side; the whole stated range lies above it.
By their numbers in this assay, from the lowest: compound 3; then compound 4; then compound 1. At a limit, above all of these: compound 2.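

In this assay, the substituent on the phenyl ring matters, though only modestly in this pair: trifluoromethyl in place of fluoro gives a 2.7-fold lower number from compound 1 to compound 4 (0.43 log units; beyond the scatter). Even so, 4-(trifluoromethyl)phenyl falls far short of 1-methyl-1H-indol-5-yl, with a 48-fold higher number from compound 3 to compound 4 (1.68 log units; beyond the scatter), so none of the three substituted phenyl groups shown comes close to compound 3. The remaining step, an at least 5.3-fold lower number from compound 2 to compound 4 (0.73 log units; beyond the scatter), is only a floor, as compound 2 gives a limit and not a number: the limit of > 10000 nM in this assay, at which 1 of the 4 values shown sits.

From the compounds shown here alone, it remains open whether the low value of compound 3 depends on having two rings or on the ring nitrogen with its methyl. A naphthyl group and a 1H-indol-5-yl group without the methyl would help separate these two features.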